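From a Bulky Group to a Small One on the Ring

This account rests on a few compounds, and the source may have more. Where it says the series, first, only, none or still open, it means among the compounds named here.

Compound 1, `CC1(C)CC12NC(=O)N(NC(=O)c1ccccc1)C2=O`: 300 mg/kg
Compound 2, `CC(C)(C)c1ccc(C(=O)NN2C(=O)NC3(CC3(C)C)C2=O)cc1`: 100 mg/kg

Both compounds share one core and differ only in a single group on the aromatic ring. In a functional assay on the whole organism for inhibition, with Mus musculus as the target, with a stated time of 0.5 h (on this read-out lower numbers stand for an effect already at smaller amounts and higher numbers for an effect only at larger amounts of compound), compound 1 gives 300 mg/kg, while compound 2 gives 100 mg/kg, the lower of the two numbers. Among the compounds with values here, the only measured step, a 3.0-fold lower number from compound 1 to compound 2 (0.48 log units; beyond the scatter), came from tert-butyl in place of hydrogen on an aromatic carbon.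

Compound 3, `CC1(C)CC12NC(=O)N(NC(=O)c1ccc(Cl)cc1)C2=O`, is not yet measured. It differs from compound 2 in this way: chloro in place of tert-butyl on an aromatic carbon. Within the data shown here, only that one step bears on the question. Chloro brings one heavy atom where tert-butyl brought four, so a number between those of compound 1 and compound 2 is expected, with the expected step of a 1.5-fold higher number from compound 2 to compound 3 (0.18 log units; within the scatter) being a modest rise. The estimate for compound 3 is 150 mg/kg, with a range from 75 mg/kg to 300 mg/kg.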

Compound 3, minimum effective dose: 300 mg/kg
Estimate against measurement, compound 3: 2.0-fold (0.30 log units) below, and the stated range covers the measured number.
By their numbers in this assay, from the lowest: compound 2; then compounds 1 and 3 (each within the scatter of the next).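

In this assay, chloro in place of tert-butyl gives a 3.0-fold higher number from compound 2 to compound 3 (0.48 log units; beyond the scatter) on the same aromatic carbon, so the gain seen with tert-butyl does not extend to every group placed there. Chloro in place of hydrogen gives no change at the digits printed from compound 1 to compound 3 (within the scatter) in this series, which shows that a group at this position is not enough by itself: of the three compounds, only compound 2 stands apart from the other two. No measurement at hand explains why tert-butyl and chloro differ here.

Going by these compounds, it remains open whether another group on this aromatic carbon, such as an amine or a longer carbon chain, would resemble tert-butyl or chloro. On these data alone, it is also open whether tert-butyl would give a similar step on a core other than the shared one.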